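The source may report more compounds than this note shows. Statements on the series, on what has been measured and on what is new or still open speak of the compounds shown alone.

Of the compounds shown here, two have so far been tested in a functional assay on CCRF-CEM cells (Homo sapiens) for inhibition, read by sulforhodamine B assay, with a stated time of 48 h, tested at 10 uM; on this read-out lower numbers stand for less inhibition of growth and higher numbers for more inhibition of growth at the one concentration tested. Compound 1 `C/C(=N\O)c1ccc(NC(=O)Cn2nc(-c3ccc(Cl)cc3)nc2N)cc1` gives 14.7% in this assay, and compound 2 `COc1cc(-c2nc(N)n(CC(=O)Nc3ccc(/C(C)=N\O)cc3)n2)cc(OC)c1OC` gives 15.5%. Compound 1 holds the lower of the two numbers, yet the gap to compound 2 lies within the scatter, so the two values show no order between them. The step under study leads from compound 1 to compound 3 `CC(=O)c1ccc(NC(=O)Cn2nc(-c3ccc(Cl)cc3)nc2N)cc1`, which has not yet been measured in this assay. The change is a group of 3 heavy atoms (2 carbon, 1 oxygen; no ring) in place of a group of 4 heavy atoms (2 carbon, 1 nitrogen, 1 oxygen; no ring), on an aromatic carbon. Among the compounds with values here, no step between two measured compounds exists as a guide. Within the data shown here, because compound 1 gives 14.7% in this assay and the change touches only one group on an aromatic carbon, the expected step is small, a number 0.3 percentage points higher from compound 1 to compound 3 (within the scatter), with no movement beyond the scatter. Compound 3 is accordingly estimated at 15% in this assay, within a range from 4% to 30%.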

Compound 3, percent growth inhibition at one concentration: 19.9%
Estimate against measurement, compound 3: 4.9 percentage points below; the measured number falls inside the stated range.
By their numbers in this assay, from the lowest: compounds 1, 2 and 3 (each within the scatter of the next).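

In this assay, within the data shown here, acetyl on an aromatic carbon para to a large group, in place of the group of 4 heavy atoms, gives a number 5.2 percentage points higher from compound 1 to compound 3 (within the scatter) and so provides the first readable step at this position. The entering group has 0 hydrogen-bond donors and no nitrogen, whereas the leaving group has 1 hydrogen-bond donor and 1 nitrogen, yet this exchange does not carry the number beyond the scatter at the one concentration tested. Nothing measured here gives a reason for this result.

On these data alone, whether an amine, a carboxylic acid or a longer chain at this position would move the number beyond the scatter remains open. Also open, as far as these compounds go, is whether acetyl in place of the same group would give a step of similar size on the core of compound 2.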